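The source may report more compounds than this note shows. Statements on the series, on what has been measured and on what is new or still open speak of the compounds shown alone.

Compound 1 `NC(=O)C[C@H](NC(=O)CN(c1nc(Cl)nc2[nH]cnc12)C1CC1)C(=O)OCc1ccccc1`: 15.1%
Compound 2 `C[C@@H](O)[C@H](NC(=O)CN(c1nc(Cl)nc2[nH]cnc12)C1CC1)C(=O)OCc1ccccc1`: 30.7%

Within the data shown here, in a functional assay on the whole organism (Tail, strain ICR) with Mus musculus as the target, in the tail flick test, with a stated time of 120 min, at a dose of 25 umol/kg by the oral route (a higher number here means a stronger effect of the compound at the dose given, a lower number a weaker effect), compound 2 stands highest of the two numbers; the only measured step is a number 15.6 percentage points higher from compound 1 to compound 2 (beyond the scatter). Compound 3 `O=C(CN(c1nc(Cl)nc2[nH]cnc12)C1CC1)N[C@@H](CO)C(=O)OCc1ccccc1` differs from compound 2 by hydrogen in place of methyl on a saturated chain carbon bound to an oxygen on a saturated carbon and a saturated chain carbon, that is 1-hydroxyethyl to hydroxymethyl. Among the measured compounds shown here, the one measured step concerns a different exchange at the chain carbon bound to the amide-type nitrogen and the carbonyl carbon, so it bears only loosely on trimming a methyl. A small step, about a number 6.7 percentage points lower from compound 2 to compound 3 (within the scatter) and possibly within the scatter, is expected. Compound 3 is estimated at 24%, range 8% to 40%.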

Compound 3, a percentage reported as activity, at one dose (the size of the read-out at that dose, not a potency): 34.5%
Beside the measured number, compound 3's estimate is 10.5 percentage points below it; the range from low to high includes it.
By their numbers in this assay, from the lowest: compound 1; then compounds 2 and 3 (each within the scatter of the next).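

In this assay, hydrogen in place of methyl, 1-hydroxyethyl to hydroxymethyl, gives a step of a number 3.8 percentage points higher from compound 2 to compound 3 (within the scatter), so this pair shows no dependence of the read-out on that methyl at this dose. Hydroxy in place of carbamoyl gives a step of a number 19.4 percentage points higher from compound 1 to compound 3 (beyond the scatter), which adds a second hydroxy-bearing side chain that stands apart from compound 1. No measurement at hand accounts for either step. Still open, on these data alone, is how an amine, a carboxylic acid or a longer chain carrying the hydroxy would read out at this position. A single dose and time also leave potency and duration of effect open.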